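Phenoxy ring substitution: expected clearance of compound 4

The source may report more compounds than this note shows. Statements on the series, on what has been measured and on what is new or still open speak of the compounds shown alone.

Values in an ADME assay on microsomes from liver (Mus musculus) for metabolic stability; on this read-out lower numbers stand for slow clearance and higher numbers for fast clearance:
compound 1 `CCS(=O)(=O)Nc1ccc(Oc2ccccc2)c(-c2cn(C)c(=O)c3[nH]ccc23)c1`: 917 mL/min/kg
compound 2 `Cn1cc(-c2cc(C(N)=O)ccc2Oc2ccccc2)c2cc[nH]c2c1=O`: 450 mL/min/kg
compound 3 `Cn1cc(-c2cc(S(N)(=O)=O)ccc2Oc2ccccc2)c2cc[nH]c2c1=O`: 517 mL/min/kg

Compound 1 stands highest of the three numbers in this assay; the step of a 1.8-fold lower number from compound 1 to compound 3 (0.25 log units; within the scatter) is within the scatter, while a 2.0-fold lower number from compound 1 to compound 2 (0.31 log units; beyond the scatter) is modest but beyond it. Compound 4 `CCS(=O)(=O)Nc1ccc(Oc2ccc(C#N)cc2)c(-c2cn(C)c(=O)c3[nH]ccc23)c1` differs from compound 1 by cyano in place of hydrogen on an aromatic carbon. Going by the values given here, none of the measured steps touches the phenoxy ring: both a 2.0-fold lower number from compound 1 to compound 2 (0.31 log units; beyond the scatter) and a 1.8-fold lower number from compound 1 to compound 3 (0.25 log units; within the scatter) exchange the group on the other aryl ring, and neither moves the number far. Among the compounds with values here, with no step bearing directly on this change, the expectation for compound 4 is no step beyond the scatter, a 1.2-fold lower number from compound 1 to compound 4 (0.09 log units; within the scatter). The estimated value for compound 4 in this assay is 750 mL/min/kg, with a range from 380 mL/min/kg to 1500 mL/min/kg.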

Compound 4, clearance: < 109 mL/min/kg
Compound 4: a limit, no number (the forecaster's own chance of this, stated with the estimate: 5%); middle value at least 6.8-fold (0.83 log units) from the limit.
By their numbers in this assay, from the lowest: compounds 2, 3 and 1 (each within the scatter of the next, the first and the last beyond it). At a limit, below all of these: compound 4.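

In this assay, the phenoxy ring proves a sensitive place in this series: 4-cyanophenoxy in place of phenoxy gives an at least 8.4-fold lower number from compound 1 to compound 4 (0.92 log units; beyond the scatter). Compound 4 gives a limit and not a number: the limit of < 109 mL/min/kg in this assay, at which 1 of the 4 values shown sits. This single change at the place para to a large group moves the number further than the exchange on the other aryl ring, a 2.0-fold lower number from compound 1 to compound 2 (0.31 log units; beyond the scatter).

Open, on these data alone, is whether chloro, methoxy or a carboxylic acid at the same place would give a similar step. Also open, as far as these compounds go, is whether cyano there would act alike alongside the carbamoyl of compound 2 or the sulfamoyl of compound 3.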